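Replacing the hydroxypyrimidine group of compound 2

The compounds below may be only part of what the source reports. "The series", "measured", "known", "first", "only" and "open" are said of these compounds alone.

Compound 2 `CCCCCCCCN(C)C(=O)Cn1cc(Cc2cnc(O)nc2)c(=O)nc1SCc1ccc(F)cc1` gives 66% in a functional assay on a cell-free system (plasma) for inhibition of platelet-activating factor acetylhydrolase (Homo sapiens), tested at 100 nM (a higher number here means more inhibition at the concentration tested (going by the name of the read-out), a lower number less inhibition), the second highest of three numbers: compound 3 `CCCCCCCCCCCCN(C)C(=O)Cn1cc(Cc2cnc(O)nc2)c(=O)nc1SCc1ccc(F)cc1` gives 83%, and compound 1 `CCCCCCCCN(C)C(=O)Cn1cc(Cc2cnc(OCc3ccccc3)nc2)c(=O)nc1SCc1ccc(F)cc1` gives 10%. Compound 4 `CCCCCCCCN(C)C(=O)Cn1cc(Cc2cnc(=O)n(CCO)c2)c(=O)nc1SCc1ccc(F)cc1` differs from compound 2 by a group of 10 heavy atoms (6 carbon, 2 nitrogen, 2 oxygen; one six-membered aromatic ring with 2 hetero atoms) in place of a group of 7 heavy atoms (4 carbon, 2 nitrogen, 1 oxygen; one six-membered aromatic ring with 2 hetero atoms), on a saturated chain carbon bound to an aromatic carbon. Of the measured steps, a number 56 percentage points higher from compound 1 to compound 2 (beyond the scatter) bears on this change: both touch the 2-hydroxypyrimidin-5-yl group, and the number fell sharply when that group carried a benzyl in compound 1. The step of a number 17 percentage points higher from compound 2 to compound 3 (beyond the scatter) alters a different part and says little here. The entering group still holds one hydrogen-bond donor, so a smaller loss than in compound 1 is expected, and the step is expected to be a number 21 percentage points lower from compound 2 to compound 4 (beyond the scatter). Compound 4 is estimated at 45%, within 15% to 75%.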

Compound 4, a percentage reported as inhibition, at one concentration (the size of the read-out at that concentration, not a potency): 59%
Beside the measured number, compound 4's estimate is 14 percentage points below it, within the range that was stated.
By their numbers in this assay, from the lowest: compound 1; then compounds 4 and 2 (each within the scatter of the next); then compound 3.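

this assay records a number 7 percentage points lower from compound 2 to compound 4 (within the scatter), so on the saturated chain carbon bound to an aromatic carbon, the group of 10 heavy atoms stands level with the 2-hydroxypyrimidin-5-yl group. Compound 1, at 10%, had shown only that a larger group here can go with a low number; compound 4 shows that more heavy atoms at this place do not by themselves bring one. Nothing at hand accounts for this result.

From the compounds shown here alone, it remains open whether an amine or a carboxylic acid in place of the hydroxyl of the entering group would hold the number. Also open, going by these compounds, is whether the longer chain of compound 3 would add to it.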